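Swapping one aryl group on compound 3

The compounds below may be only part of what the source reports. "The series", "measured", "known", "first", "only" and "open" are said of these compounds alone.

In a functional assay on U-87MG ATCC cells for antiproliferative activity against U-87 MG (Homo sapiens), read by spectrophotometry, with a stated time of 2 days (a higher number here means a weaker inhibitor of growth, a lower number a stronger inhibitor of growth), compound 3 `COc1cc(Nc2ncc(C(F)(F)F)c(N3Cc4cccc(N(C)S(C)(=O)=O)c4C3)n2)c(OC)cc1Cl` gives 6200 nM as the lower of the two actual numbers, and compound 1 `CC(=O)N1CCN(c2ccc(Nc3ncc(C(F)(F)F)c(N4Cc5cccc(N(C)S(C)(=O)=O)c5C4)n3)cc2)CC1` gives 22100 nM as the other. Compound 2 `COc1ccc(C(F)(F)F)cc1Nc1ncc(C(F)(F)F)c(N2Cc3cccc(N(C)S(C)(=O)=O)c3C2)n1` stands at > 30000 nM as a limit of the assay, not a number. The change to compound 4 `CN(c1cccc2c1CN(c1nc(Nc3ccc(C(F)(F)F)cc3)ncc1C(F)(F)F)C2)S(C)(=O)=O` is 4-(trifluoromethyl)phenyl in place of 4-chloro-2,5-dimethoxyphenyl on a nitrogen on an aromatic ring and puts 4-(trifluoromethyl)phenyl in place of 4-chloro-2,5-dimethoxyphenyl on a nitrogen on an aromatic ring. Going by the values given here, the one measured step at that nitrogen, an at least 4.8-fold lower number from compound 2 to compound 3 (0.68 log units; beyond the scatter) in size, brought in the group now leaving and removed another group carrying trifluoromethyl. A higher number, meaning weaker growth inhibition, is therefore expected, estimated as a 2.4-fold higher number from compound 3 to compound 4 (0.38 log units; beyond the scatter) in size. The estimate for compound 4 is 15000 nM with 5000 nM to 30000 nM as its expected range.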

Compound 4, concentration for 50% growth inhibition: > 30000 nM
Compound 4 gave a limit, no number; the forecaster's own chance of this, stated with the estimate: 25%; at least 2.0-fold (0.30 log units) between middle value and limit.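

With the value of compound 4 being a limit and not a number, the swap at this nitrogen still reads as an at least 4.8-fold higher number from compound 3 to compound 4 (0.68 log units; beyond the scatter), so 4-chloro-2,5-dimethoxyphenyl now outperforms both trifluoromethyl-bearing aryl groups shown. Trifluoromethyl in place of 4-acetylpiperazin-1-yl gives an at least 1.3-fold higher number from compound 1 to compound 4 (0.13 log units; that floor lies within the scatter), which does not establish a real change. The step between compound 2 and compound 4 cannot be read: the limit of > 30000 nM in this assay, at which 2 of the 4 values shown sit.

Going by these compounds, how weak compound 4 really is stays unknown. So does whether an amine or a carboxylic acid on this aryl ring would give stronger growth inhibition than compound 3.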